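The compounds below may be only part of what the source reports. "The series", "measured", "known", "first", "only" and "open" are said of these compounds alone.

Measured so far in a physicochemical assay for lipophilicity, in phosphate buffer, measured as octanol-water partition, with a stated time of 24 h; on this read-out higher numbers stand for higher lipophilicity and lower numbers for lower lipophilicity:
compound 1, `S=C(N/N=C/c1ccc(Oc2ccccc2)cc1)Nc1ccc(Cl)cc1`, gives 5.64.
compound 2, `O=[N+]([O-])c1ccc(Oc2ccc(/C=N/NC(=S)Nc3ccc(Br)cc3)cc2)cc1`, gives 5.68.
compound 3, `O=[N+]([O-])c1ccc(Oc2ccc(/C=N/NC(=S)Nc3ccccc3)cc2)cc1`, gives 4.95.

Compound 3 stands lowest of the three numbers in this assay. Its nearest neighbour is compound 1, which sits higher by a margin beyond the scatter, and the furthest is compound 2, higher still.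

The next compound, compound 4 `O=[N+]([O-])c1ccc(Oc2ccc(/C=N/NC(=S)Nc3ccc(Cl)cc3)cc2)cc1`, is not yet measured. It differs from compound 3 in one place: chloro in place of hydrogen on an aromatic carbon. The new group sits on an aromatic carbon of a six-membered aromatic ring of carbon only, para to a large group.

Within the data shown here, one measured step bears directly on this change. Going a number 0.73 log units lower from compound 2 to compound 3 (beyond the scatter), so removing a bromo from that same position pulled the number down by a modest amount. Putting a chloro back in the same place is expected to move it the other way, by a step of similar size: compound 4 is estimated to come out a number 0.65 log units higher from compound 3 to compound 4 (beyond the scatter). Compound 1 carries a chloro at that position without the nitro group and gives 5.64, which fits the same picture. The estimate for compound 4 is therefore 5.6, with a likely range from 5.3 to 5.9.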

Compound 4, partition coefficient: 5.52
For compound 4 the middle estimate is 0.08 log units above the measured one; low and high end bracket the measured number.
By their numbers in this assay, from the lowest: compound 3; then compounds 4, 1 and 2 (each within the scatter of the next).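

Until now this position had only been read through the loss of a bromo; compound 4 adds a second halogen to the same place, on an aromatic carbon para to a large group, and in this assay the change from hydrogen to chloro gives a number 0.57 log units higher from compound 3 to compound 4 (beyond the scatter), a rise beyond the scatter. The choice between the two halogens makes no clear difference, since the swap from bromo to chloro gives a number 0.16 log units lower from compound 2 to compound 4 (within the scatter), which lies within the scatter, so among these compounds the clear divide is between hydrogen and a halogen, not between chloro and bromo. Among these compounds, compound 4 also gives the first one-place reading of the nitro group, and with chloro already in place, nitro in place of hydrogen gives a number 0.12 log units lower from compound 1 to compound 4 (within the scatter), again within the scatter, so this change shows no clear effect on the number here.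

Nothing measured alongside these numbers offers a reason for any of these steps. Still open is how the number would respond at this same position to fluoro, to a methoxy group or an amine, or to a carboxylic acid, none of which is among the compounds shown.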